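A few compounds are considered here, and "the series" means these few. Any claim that something is new, unique, unknown or untested is made for them only; others in the source may bear on it.

Of the compounds shown here, three built on one shared core have been measured in a functional assay on U-251 cells (Homo sapiens) for inhibition, read by sulforhodamine B assay, with a stated time of 48 h, tested at 100 uM; on this read-out lower numbers stand for a stronger effect and higher numbers for a weaker effect at the one concentration tested. Compound 1 `COc1cc(Cl)cc(-c2nn(-c3cccc(NC(=O)Nc4ccc(Cl)c(C(F)(F)F)c4)c3)cc2-c2ccncc2)c1` gives -100%. Compound 2 `COc1cc(Cl)cc(-c2nn(-c3cccc(NC(=O)Nc4cc(C(F)(F)F)cc(C(F)(F)F)c4)c3)cc2-c2ccncc2)c1` gives -92% in this assay. Compound 3 `COc1cc(Cl)cc(-c2nn(-c3cccc(NC(=O)Nc4ccc(Cl)c(Cl)c4)c3)cc2-c2ccncc2)c1` gives -68% in this assay, the highest of the three numbers, separated from both others by more than the scatter; compound 2 stands nearest to it and compound 1 furthest. Going by the values given here, only one single-point step among the measured compounds is available: a number 32 percentage points higher from compound 1 to compound 3 (beyond the scatter). Compound 4 `COc1cc(Cl)cc(-c2nn(-c3cccc(NC(=O)Nc4cccc(C(F)(F)F)c4)c3)cc2-c2ccncc2)c1` has not yet been measured. It differs from compound 3 in one place: 3-(trifluoromethyl)phenyl in place of 3,4-dichlorophenyl on an amide-type nitrogen. Among the compounds with values here, the change partly runs back along the measured step, since a trifluoromethyl enters where compound 1 carried one, yet it also removes a second chloro, for which no measured pair gives guidance. Within the data shown here, compound 4 is therefore expected to give a lower number than compound 3, though a smaller move than the one seen between compound 1 and compound 3. The expected step is a number 16 percentage points lower from compound 3 to compound 4 (beyond the scatter). Compound 4 is estimated at -84%, within -100% to -60%.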

Compound 4, a percentage reported as activity, at one concentration (the size of the read-out at that concentration, not a potency): -100%
Beside the measured number, compound 4's estimate is 16 percentage points above it, within the range that was stated.
By their numbers in this assay, from the lowest: compounds 1, 4 and 2 (each within the scatter of the next); then compound 3.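

In this assay, the step of a number 32 percentage points lower from compound 3 to compound 4 (beyond the scatter) shows that this aryl group on the amide-type nitrogen matters: 3-(trifluoromethyl)phenyl alone does what 3,4-dichlorophenyl does not. Neither extra group on the trifluoromethyl-bearing ring is needed, since hydrogen in place of chloro gives no change at the digits printed from compound 1 to compound 4 (within the scatter) and hydrogen in place of the second trifluoromethyl gives a number 8 percentage points lower from compound 2 to compound 4 (within the scatter). Among these four compounds, the three that carry trifluoromethyl sit together, and compound 3, which carries none, stands apart.

Nothing at hand explains why the trifluoromethyl group and the two chloro groups part in this way. On these data alone, it remains open whether a 3-chlorophenyl group, or a nitrile, a methoxy group or an amine in the place of the trifluoromethyl, would keep the read-out of compound 4.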